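The source may hold more compounds than are shown below. What is called first, only, known or untested is meant among the compounds shown, and "the series" means these compounds.

Among the compounds with values here, only two compounds have been measured so far in a functional assay on A549 cells (Homo sapiens) for antiproliferative activity, read by MTT assay, with a stated time of 48 h; on this read-out higher numbers stand for weaker inhibition and lower numbers for stronger inhibition. Compound 1 `O=C(/C=C/c1ccc(Br)cc1)Nc1cc(-c2ccc(Br)cc2)[nH]n1` gives 1360 nM, and compound 2 `O=C(/C=C/c1ccc(Cl)cc1)Nc1cc(-c2ccc(Br)cc2)[nH]n1` gives 1210 nM. Within the data shown here, compound 1 therefore cannot be told apart from its only measured neighbour: exchanging bromo for chloro on an aromatic carbon produces a 1.1-fold lower number from compound 1 to compound 2 (0.05 log units; within the scatter).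

Compound 3 `Cc1ccc(-c2cc(NC(=O)/C=C/c3ccc(Br)cc3)n[nH]2)cc1` has not yet been measured. It differs from compound 1 by methyl in place of bromo on an aromatic carbon. This places methyl in place of bromo on an aromatic carbon, para to a large group, turning 4-bromophenyl into 4-methylphenyl.

Among the measured compounds shown here, the single measured step offers only loose guidance. It changes the other bromo of compound 1, and it brings in another halogen rather than a methyl. For the measured compounds named here, no measurement yet shows how this 4-bromophenyl position responds to change, so no shift beyond the scatter is expected, although the uncertainty is wide. The expected result is a 1.3-fold higher number from compound 1 to compound 3 (0.10 log units; within the scatter). For compound 3, the estimated value is 1700 nM, with an expected range of 650 nM to 4000 nM.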

Compound 3, half-maximal inhibitory concentration: 1590 nM
Estimate against measurement, compound 3: 1.1-fold (0.03 log units) above, within the range that was stated.
By their numbers in this assay, from the lowest: compounds 2, 1 and 3 (each within the scatter of the next).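

Within the data shown here, this is the first look at the 4-bromophenyl end of compound 1. In this assay, turning 4-bromophenyl into 4-methylphenyl gives a 1.2-fold higher number from compound 1 to compound 3 (0.07 log units; within the scatter), so replacing bromo with methyl at this position leaves the number within the scatter, and compound 3 keeps its activity with no halogen on this ring. Each of the two aromatic bromo groups of compound 1 has now been changed once, and neither single change has moved the number beyond the scatter, although this holds only for these three compounds and there is no measured information on why the number stays put here.

Bromo and methyl each bring a single heavy atom and no hydrogen-bond donor or acceptor, so the compounds shown cover only a narrow kind of change at this position. An amine, a carboxylic acid or a longer chain such as butyl on this ring could show whether the position responds at all, and a methyl on the other aromatic ring would show whether the same exchange also holds there.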